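The source may hold more compounds than are shown below. What is called first, only, known or untested is meant among the compounds shown, and "the series" means these compounds.

Compound 2 `CCC(C)(C)Cc1c[nH]c(CCc2ccc(-c3cccc(C#N)n3)cc2)n1` carries a 6-cyanopyridin-2-yl group on an aromatic carbon of its core; compound 1 `CCC(C)(C)Cc1c[nH]c(CCc2ccc(-n3cccn3)cc2)n1` has a 1H-pyrazol-1-yl group at that same carbon. In a functional assay on HEK293 cells for agonist activity at Bombesin receptor subtype-3 (Mus musculus), read by luminescence and calcium flux, with a stated time of 10 min (a lower number here means that less compound is needed, a higher number that more compound is needed for the effect), compound 2 gives 26 nM, the highest of the three numbers recorded. Compound 1 gives 9 nM in this assay, and compound 3 `c1ccc(-c2ccc(CCc3nc(CC4CCCC4)c[nH]3)cc2)nc1`, built on a different core, gives 22 nM. Compound 2 and compound 3 lie within the scatter of each other, while the gap between compound 1 and compound 2 is beyond it.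

Going by the values given here, compound 4 `CCC(C)(C)Cc1c[nH]c(CCc2ccc(-c3ccns3)cc2)n1` has not yet been measured. 1,2-thiazol-5-yl in place of 6-cyanopyridin-2-yl on an aromatic carbon The single measured step that bears on this is a 2.9-fold higher number from compound 1 to compound 2 (0.46 log units; beyond the scatter), in which a group containing one five-membered aromatic ring with 2 hetero atoms gave way to the 6-cyanopyridin-2-yl group. The move to 1,2-thiazol-5-yl brings back a five-membered aromatic ring with 2 hetero atoms, so a partial reversal of that step is expected, with the number for compound 4 most likely falling between those of compound 1 and compound 2. Compound 4 is therefore estimated at 15 nM, within a range of 5 nM to 45 nM, an expected step of a 1.7-fold lower number from compound 2 to compound 4 (0.24 log units; within the scatter) toward a lower number that may not exceed the scatter.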

Compound 4, half-maximal effective concentration: 3.1 nM
Beside the measured number, compound 4's estimate is 4.8-fold (0.68 log units) above it; measured number below the stated range.
By their numbers in this assay, from the lowest: compound 4; then compound 1; then compounds 3 and 2 (each within the scatter of the next).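

Going by these compounds alone, at this position, on an aromatic carbon of a six-membered aromatic ring of carbon only and para to a large group, replacing 6-cyanopyridin-2-yl with 1,2-thiazol-5-yl in this assay gives an 8.4-fold lower number from compound 2 to compound 4 (0.92 log units; beyond the scatter), so the number for this series can fall past the lowest one the earlier compounds reached. Ring size alone does not settle the number: 1H-pyrazol-1-yl and 1,2-thiazol-5-yl each bring one five-membered aromatic ring with 2 hetero atoms, yet exchanging the first for the second gives a 2.9-fold lower number from compound 1 to compound 4 (0.46 log units; beyond the scatter), which shows that two groups of this shared ring type can be told apart in this assay. Nothing measured here accounts for this difference between the two groups.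

The nitrile and the six-membered ring leave together in the change from compound 2 to compound 4, so the compounds shown do not separate their contributions, and a plain pyridin-2-yl group on the same core would be needed to do so. From the compounds shown here alone, it also remains open whether a methyl group or an amine on the 1,2-thiazole ring would be tolerated, and whether 1,2-thiazol-5-yl would give a similar result on the core of compound 3.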